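A few compounds are considered here, and "the series" means these few. Any claim that something is new, unique, unknown or untested is made for them only; others in the source may bear on it.

Measured in a functional assay on the whole organism (strain Wistar) for inhibition, with Rattus norvegicus as the target, read by paw edema, with stated times of 60 min and 2 h, at a dose of 100 mg/kg by the oral route; a lower number here means less inhibition, a higher number more inhibition at the dose given (going by the name of the read-out):

compound 1 `COc1cc2c(cc1OC)C(CC(=O)O)CC2`: 24%
compound 2 `CCNC(=O)CC1CCc2cc(OC)c(OC)cc21`: 26%
compound 3 `COc1cc2c(cc1OC)C(CC(=O)NC(C)(C)C)CC2`: 32%

Compound 3 carries the highest of the three numbers, yet its separation from the others is small: the step of a number 6 percentage points higher from compound 2 to compound 3 (within the scatter) and the step of a number 8 percentage points higher from compound 1 to compound 3 (within the scatter) both stay within the scatter, so no order among compounds 1, 2 and 3 can be claimed.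

The next compound, compound 4 `CCCCCCNC(=O)CC1CCc2cc(OC)c(OC)cc21`, differs from compound 3 only on the amide-type nitrogen: hexyl in place of tert-butyl on an amide-type nitrogen.

Within the data shown here, the steps that bear on this change are those at the same nitrogen. Replacing hydroxy by ethylamino gave a number 2 percentage points higher from compound 1 to compound 2 (within the scatter), and replacing ethyl by tert-butyl gave a number 6 percentage points higher from compound 2 to compound 3 (within the scatter); neither left the scatter. Every alteration at the carbonyl-attached nitrogen so far has therefore moved the read-out by no more than the noise of the measurement. On that basis no step beyond the scatter is expected in this assay for compound 4 either, in either direction: the estimated step is a number 2 percentage points lower from compound 3 to compound 4 (within the scatter).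

For compound 4 the expected value is 30%, with a range from 18% to 42%.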

Compound 4, a percentage reported as inhibition, in the whole organism at one dose (the size of the read-out at that dose, not a potency): 41.5%
For compound 4 the middle estimate is 11.5 percentage points below the measured one, within the range that was stated.
By their numbers in this assay, from the lowest: compounds 1, 2, 3 and 4 (each within the scatter of the next, the first and the last beyond it).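

Among these compounds, on the amide-type nitrogen, hexyl gives the first steps in this assay that leave the scatter, with a number 15.5 percentage points higher from compound 2 to compound 4 (beyond the scatter) and with a number 17.5 percentage points higher from compound 1 to compound 4 (beyond the scatter) as well. The change from tert-butyl to hexyl gives a number 9.5 percentage points higher from compound 3 to compound 4 (within the scatter), so hexyl stands apart from ethyl and from hydroxy on the carbonyl carbon, but not from tert-butyl. The data offer no explanation for these steps.

From the compounds shown here alone, whether the number goes on rising with a chain longer than hexyl, such as octyl or decyl, remains open, as does the result for butyl or for a ring such as cyclohexyl on the same nitrogen. A single oral dose also leaves open whether compound 4 would keep its separation from ethyl at other doses.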